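The source may hold more compounds than are shown below. What is called first, only, known or untested is meant among the compounds shown, and "the series" means these compounds.

Working notes on a series built on one shared core. In a functional assay on NCI-H23 cells (Homo sapiens) for inhibition, read by sulforhodamine B assay, with a stated time of 48 h (on this read-out higher numbers stand for weaker inhibition of growth and lower numbers for stronger inhibition of growth), compound 1 `Nc1cc(N)c2nc(-c3ccccc3)c(NCc3ccc(Cl)c(Cl)c3)nc2c1` gives 14100 nM, and compound 2 `CCOC(=O)[C@H](CCC(=O)O)NC(=O)c1ccc(Sc2nc3cc(N)cc(N)c3nc2-c2ccccc2)cc1` gives 11700 nM; these two values lie within the scatter of each other. Compound 3 `COc1ccc(Sc2nc3cc(N)cc(N)c3nc2-c2ccccc2)cc1` stands apart from both. In this assay compound 3 gives only < 100000 nM, which is a limit of the assay and not a number; it marks (the limit of < 100000 nM in this assay, at which 1 of the 3 values shown sits). For the measured compounds named here, no pair of measured compounds differs in a single place, so no measured step is at hand to size the change now considered. Compound 4 `Nc1cc(N)c2nc(-c3ccccc3)c(Sc3ccc(F)cc3)nc2c1` is the next member to be measured in this assay. It differs from compound 3 by fluoro in place of methoxy on an aromatic carbon. Because compound 3 is known only as < 100000 nM, the direction of the step cannot be read from the data, and no shift beyond the scatter is assumed. The expected step is a step that the limit leaves unreadable from compound 3 to compound 4. For compound 4 in this assay the estimated value is 25000 nM, with a range from 6000 nM to 95000 nM.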

Compound 4, concentration for 50% growth inhibition: 19100 nM
Compound 4: the middle estimate sits 1.3-fold (0.12 log units) above what was measured; the measured number falls inside the stated range.
By their numbers in this assay, from the lowest: compounds 2, 1 and 4 (each within the scatter of the next).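

In this assay no step can be read from compound 3 to compound 4, because compound 3 stands only at a limit: the limit of < 100000 nM in this assay, at which 1 of the 4 values shown sits.
The compounds shown leave open what fluoro in place of methoxy on an aromatic carbon does to growth inhibition when both partners carry a number.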